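This account rests on a few compounds, and the source may have more. Where it says the series, first, only, none or still open, it means among the compounds named here.

Of the compounds shown here, three with a shared core have been measured in the same whole-animal read-out. Compound 1 `Oc1ccc(/C=N/NC(=S)Nc2nc3ccc(Cl)cc3s2)cc1` gives 100 mg/kg in a functional assay on the whole organism with Mus musculus as the target, with a stated time of 0.5 h; on this read-out higher numbers stand for an effect only at larger amounts of compound and lower numbers for an effect already at smaller amounts. Compound 2 `CC(C)(C)NCC(=O)Nc1nc2ccc(Cl)cc2s1` gives 100 mg/kg in this assay, and compound 3 `O=C(Cn1ccnc1)Nc1nc2ccc(Cl)cc2s1` gives 100 mg/kg. Among the measured compounds shown here, the only step between compounds that differ in one place, no change at the digits printed from compound 2 to compound 3 (within the scatter), replaces (tert-butyl)amino with 1H-imidazol-1-yl on a saturated chain carbon bound to a carbonyl carbon and leaves the minimum effective dose unchanged within the scatter. Compound 3 therefore stands level with compound 1 and compound 2 at the digits shown, with no compound of the three set apart from the others.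

Compound 4 `O=C(CN1CCCCC1)Nc1nc2ccc(Cl)cc2s1` is not yet measured. It differs from compound 3 as follows: piperidin-1-yl in place of 1H-imidazol-1-yl on a saturated chain carbon bound to a carbonyl carbon. The step of no change at the digits printed from compound 2 to compound 3 (within the scatter) is the only measured one that touches the same place, and it showed no change beyond the scatter, so a group swap at this position has so far left the read-out flat. On that basis compound 4 is expected to show no step beyond the scatter from compound 3, that is no change at the digits printed from compound 3 to compound 4 (within the scatter). The estimated minimum effective dose for compound 4 in this assay is 100 mg/kg, with a range from 50 mg/kg to 200 mg/kg.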

Compound 4, minimum effective dose in the Mus musculus assay: 100 mg/kg
Beside the measured number, compound 4's estimate shows no gap at the digits printed, and the stated range covers the measured number.
By their numbers in the Mus musculus assay, from the lowest: compounds 1, 2, 3 and 4 (each within the scatter of the next).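

In the Mus musculus assay, piperidin-1-yl also leaves the read-out flat, with no change at the digits printed from compound 3 to compound 4 (within the scatter) and no change at the digits printed from compound 2 to compound 4 (within the scatter), so on a saturated chain carbon bound to a carbonyl carbon, (tert-butyl)amino, a five-membered aromatic ring and a six-membered non-aromatic ring all give the same printed dose. The same change is not silent everywhere: in a physicochemical assay for lipophilicity, in phosphate buffer, measured as octanol-water partition (on this read-out higher numbers stand for higher lipophilicity and lower numbers for lower lipophilicity), compound 3 gives 2.14 and compound 4 gives 3.16, which is a number 1.02 log units higher from compound 3 to compound 4 (beyond the scatter). For this pair, then, a large rise in lipophilicity comes with no shift in the minimum effective dose: the measured partition coefficient of compound 3, 2.14, and of compound 4, 3.16, a number 1.02 log units higher (beyond the scatter)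

All four compounds stand level in the Mus musculus assay, so these compounds do not show whether any change at this place can move the dose at all, or what the dose would do at a different lipophilicity. On these data alone, a carboxylic acid or a morpholin-4-yl group on the same chain carbon, or a longer chain carrying the piperidin-1-yl group, would test this position further, and the effect of replacing the chlorine on the shared core remains open as well.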